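The compounds below may be only part of what the source reports. "The series", "measured", "known", "first", "only" and "open" are said of these compounds alone.

In an assay on isolated protein for inhibition of tyrosine-protein kinase receptor UFO (Homo sapiens), read by LC-MS (on this read-out higher numbers stand for weaker inhibition and lower numbers for stronger inhibition), compound 2 `Cc1ccccc1-c1ccc(-c2nnc(N(C)Cc3ccc4nccn4c3)o2)cc1` gives 631 nM, compound 1 `CN(Cc1ccc2nccn2c1)c1nnc(-c2ccc(-c3ccccc3C#N)cc2)o1` gives 3980 nM, and compound 3 `Cc1cc(-c2c(C)nn(C)c2C)ccc1-c1nnc(N(C)Cc2ccc3nccn3c2)o1` gives 79.4 nM. Compound 3 stands lowest of the three, beyond the scatter against both others. Within the pair of measured analogues, the change cyano in place of methyl on an aromatic carbon made the step of a 6.3-fold higher number from compound 2 to compound 1 (0.80 log units; beyond the scatter), a modest loss.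

Compound 4 `Cc1nn(C)c(C)c1-c1ccc(-c2nnc(N(C)Cc3ccc4nccn4c3)o2)c(C#N)c1` is not yet measured in this assay. It differs from compound 3 by cyano in place of methyl on an aromatic carbon. The difference between the cores of compound 2 and compound 3 is not broken down here. The surroundings of the changed carbon are not identical in the two pairs: in compound 4 it is also meta to a 1,3,5-trimethyl-1H-pyrazol-4-yl group, so the change is the same kind of change, not the same.

For compound 4 a step of a 6.3-fold higher number from compound 3 to compound 4 (0.80 log units; beyond the scatter) is expected, resting on the earlier step of a 6.3-fold higher number from compound 2 to compound 1 (0.80 log units; beyond the scatter) for the same kind of change. Compound 4 is estimated at 500 nM, with a likely range from 150 nM to 1600 nM.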

Compound 4, half-maximal inhibitory concentration: > 100000 nM
Compound 4: only a limit was reported (the forecaster's own chance of this, stated with the estimate: 3%); middle value at least 200-fold (2.30 log units) away from the limit.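

Across the two cores, cyano in place of methyl on an aromatic carbon did not give a step of one size in this assay: the same change on two cores in this assay, a 6.3-fold higher number (0.80 log units; beyond the scatter) from compound 2 to compound 1 and an at least 1200-fold higher number (3.10 log units; beyond the scatter) from compound 3 to compound 4, at least 190-fold (2.30 log units) apart, beyond the scatter of two such steps. On the core of compound 3 the change gave an at least 1200-fold higher number from compound 3 to compound 4 (3.10 log units; beyond the scatter), in the same direction as on the other core, so the direction carried across and the size did not. Going by these compounds, the value of compound 4 is a limit and not a number, so the full size of its step stays unknown, and two pairs whose changed carbons have different surroundings cannot show which feature of the cores sets the gap: the limit of > 100000 nM in this assay, at which 1 of the 4 values shown sits.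

Open, on these data alone, is whether the loss on this core belongs to the nitrile itself or to any replacement of that methyl, which a chlorine atom or a methoxy group on the same carbon of compound 3 would help to separate. Also open is what part the 1,3,5-trimethyl-1H-pyrazol-4-yl group plays, as no pair shown isolates it.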